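The source may hold more compounds than are shown below. What is called first, only, known or untested is meant among the compounds shown, and "the series" means these compounds.

Compound 1 `O=C(Nc1ccccc1)Nc1ccc(C(=O)NO)cc1`: 530 nM
Compound 2 `O=C(/C=C/c1ccc(NC(=O)Nc2ccccc2)cc1)NO`: 300 nM

Within the data shown here, in a functional assay on NAMALVA cells (Homo sapiens) for cytotoxicity, read by MTT assay, with a stated time of 72 h (a lower number here means a stronger inhibitor, a higher number a weaker inhibitor), compound 2 gives 300 nM, the lowest number so far, though still within the scatter of compound 1. Compound 3 `O=C(CCc1ccc(NC(=O)Nc2ccccc2)cc1)NO` carries 2-(hydroxycarbamoyl)ethyl in place of 2-(hydroxycarbamoyl)ethenyl on an aromatic carbon, para to a large group (2-(hydroxycarbamoyl)ethyl in place of 2-(hydroxycarbamoyl)ethenyl on an aromatic carbon). Among the measured compounds shown here, only one measured step bears on this chain, a 1.8-fold lower number from compound 1 to compound 2 (0.25 log units; within the scatter), where 2-(hydroxycarbamoyl)ethenyl replaced hydroxycarbamoyl, and no measured step tests 2-(hydroxycarbamoyl)ethyl itself. No change beyond the scatter is therefore expected in this assay, and the estimate is a 1.3-fold higher number from compound 2 to compound 3 (0.12 log units; within the scatter). For compound 3 the expected value is 400 nM, with an estimated range of 150 nM to 1000 nM.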

Compound 3, half-maximal inhibitory concentration: 780 nM
Beside the measured number, compound 3's estimate is 2.0-fold (0.29 log units) below it; measured number inside the range.
By their numbers in this assay, from the lowest: compounds 2, 1 and 3 (each within the scatter of the next, the first and the last beyond it).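

In this assay, among these compounds, the change from 2-(hydroxycarbamoyl)ethenyl to 2-(hydroxycarbamoyl)ethyl gives a 2.6-fold higher number from compound 2 to compound 3 (0.41 log units; beyond the scatter) and is the first step at this position to pass the scatter, so the double bond of the chain has a modest bearing on the number. Set against plain hydroxycarbamoyl, the same 2-(hydroxycarbamoyl)ethyl gives a 1.5-fold higher number from compound 1 to compound 3 (0.17 log units; within the scatter) and is not separated from it. Nothing available explains the loss seen on saturation. On these data alone, a longer chain, or a carboxylic acid in place of the hydroxycarbamoyl end, remains open in this assay and could show how far this position tolerates change.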